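Phenyl replacing the four-membered ring group

The source may hold more compounds than are shown below. What is called first, only, known or untested is meant among the compounds shown, and "the series" means these compounds.

In a functional assay on the whole organism (Hindlimb, strain albino) with Mus musculus as the target, in the maximal electroshock model, with a stated time of 0.5 h (a lower number here means that less compound is needed, a higher number that more compound is needed for the effect), compound 1 `COc1ccc(C2CC(Nc3nc4ccc(C)cc4s3)=NN2C(C)=O)cc1` gives 37.3 umol/kg, compound 2 `CC(=O)N1N=C(Nc2nc3ccccc3s2)CC1c1ccccc1` gives 315 umol/kg and compound 3 `CC(=O)N1N=C(Nc2nc3ccc(C)cc3s2)CC1OC1=CC=C1` gives 160 umol/kg. Compound 3 thus lies within the scatter of compound 2, and both stand well apart from compound 1.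

The next structure is compound 4 `CC(=O)N1N=C(Nc2nc3ccc(C)cc3s2)CC1c1ccccc1`. The change is a group of 6 heavy atoms (6 carbon; one six-membered aromatic ring of carbon only) in place of a group of 5 heavy atoms (4 carbon, 1 oxygen; one four-membered non-aromatic ring of carbon only), on a saturated ring carbon: phenyl enters where the group with the four-membered non-aromatic ring leaves, on a saturated ring carbon of a five-membered non-aromatic ring with 2 nitrogen.

Among the compounds with values here, only one measured step touches this place: a 4.3-fold higher number from compound 1 to compound 3 (0.63 log units; beyond the scatter), which is modest and beyond the scatter. There, a group with a six-membered aromatic ring gives way to the same four-membered ring group. Read in reverse, that step points to a lower number for compound 4 in this assay.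

The reverse reading cannot be taken at full size. Compound 2 also carries phenyl at this carbon and gives 315 umol/kg, and the data do not show how much of the step would carry over to plain phenyl. Only a partial move is therefore expected, and the expected change is a 1.6-fold lower number from compound 3 to compound 4 (0.20 log units; within the scatter). For compound 4 the estimated value is 100 umol/kg, with an expected range of 40 umol/kg to 250 umol/kg.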

Compound 4, dose for half-maximal effect: 106 umol/kg
The estimate for compound 4 lay 1.1-fold (0.03 log units) below the measured number; the measured number falls inside the stated range.
By their numbers in this assay, from the lowest: compound 1; then compounds 4, 3 and 2 (each within the scatter of the next, the first and the last beyond it).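

At the saturated ring carbon in this assay, phenyl in place of the group with the four-membered non-aromatic ring gives a 1.5-fold lower number from compound 3 to compound 4 (0.18 log units; within the scatter), so the two groups are not told apart at this position. The steps beyond the scatter lie on aromatic carbons instead: methyl in place of hydrogen gives a 3.0-fold lower number from compound 2 to compound 4 (0.47 log units; beyond the scatter), and hydrogen in place of methoxy gives a 2.8-fold higher number from compound 1 to compound 4 (0.45 log units; beyond the scatter). This last step isolates methoxy as the one difference between the two compounds, which a 4.3-fold higher number from compound 1 to compound 3 (0.63 log units; beyond the scatter) could not do, since the whole group on the saturated ring carbon changed there.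

No measured data bear on what lies behind the size of these steps. As far as these compounds go, what an amine or a carboxylic acid on an aromatic carbon, or a longer chain such as ethoxy in place of methoxy, would give in this assay stays open.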